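The source may report more compounds than this note shows. Statements on the series, on what has been measured and on what is new or still open speak of the compounds shown alone.

- compound 1 `CC(C)[C@@H](c1ccc(-c2ccc3cccc(F)c3c2)[nH]c1=O)[C@@H]1OC(=O)NC1=O`: 27400 nM
- compound 2 `CC(C)C(c1ccc(-c2ccc3cccc(F)c3c2)[nH]c1=O)C1NC(=O)NC1=O`: 10600 nM
- compound 3 `O=C1NC(=O)/C(=C/C2(c3ccc(-c4ccc5cccc(F)c5c4)[nH]c3=O)CCCC2)O1`: 24500 nM

These three values come from a physicochemical assay for solubility, in phosphate buffer, measured as kinetic solubility; on this read-out higher numbers stand for higher solubility and lower numbers for lower solubility. Compound 2, at 10600 nM, has the lowest number of the three. Compound 3 and compound 1 each stand higher by a margin beyond the scatter.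

The next compound to be read out is compound 4 `CC(C)C(CC1NC(=O)NC1=O)c1ccc(-c2ccc3cccc(F)c3c2)[nH]c1=O`. Its difference from compound 2 is (2,5-dioxoimidazolidin-4-yl)methyl in place of 2,5-dioxoimidazolidin-4-yl on a saturated chain carbon bound to an aromatic carbon and a saturated chain carbon. In words, (2,5-dioxoimidazolidin-4-yl)methyl stands in place of 2,5-dioxoimidazolidin-4-yl on a saturated chain carbon bound to an aromatic carbon and a saturated chain carbon.

Among the compounds with values here, the measured compounds differ from one another in more than one place, so no measured step speaks directly to this change. The expectation therefore rests on compound 2 and its value of 10600 nM, as the closest measured structure. In this assay, the expected step is a 1.2-fold lower number from compound 2 to compound 4 (0.07 log units; within the scatter), which is estimated to be slightly downward and no larger than the scatter. With so little evidence, the range has to stay wide. For compound 4 the estimated value is 9000 nM, with an expected range from 3000 nM to 27000 nM.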

Compound 4, solubility: 12300 nM
Compound 4: the middle estimate sits 1.4-fold (0.14 log units) below what was measured; the range from low to high includes it.
By their numbers in this assay, from the lowest: compounds 2, 4, 3 and 1 (each within the scatter of the next, the first and the last beyond it).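

Within the data shown here, this is the first pair that differs in only one place, so it gives the first direct reading at the saturated chain carbon bound to an aromatic carbon and a saturated chain carbon. In this assay, putting (2,5-dioxoimidazolidin-4-yl)methyl in place of 2,5-dioxoimidazolidin-4-yl gives a 1.2-fold higher number from compound 2 to compound 4 (0.06 log units; within the scatter), so this single change, which leaves the ring and the hydrogen-bond donor and acceptor counts as they were, does not separate the two compounds on this read-out. No measurement in hand bears on the reason for this result.

This one step leaves open whether a carboxylic acid, an amine or a longer chain carrying the same ring at this place would give a step beyond the scatter in this assay. It also leaves open whether the same change would read the same way with the ring of compound 1 or on the core of compound 3, since neither compound forms a one-place pair with compound 2 or compound 4.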